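A few compounds are considered here, and "the series" means these few. Any claim that something is new, unique, unknown or untested is made for them only; others in the source may bear on it.

The measured compounds in a functional assay on HT-29 cells (Homo sapiens) for cytotoxicity, read by MTT assay, with a stated time of 72 h (a lower number here means a stronger inhibitor, a higher number a weaker inhibitor), are:
compound 1, `CN(C)CCn1cnnc1-c1cc(Oc2ccc(NC(=O)N/N=C/c3cccc(O)c3)cc2F)ccn1`, 330 nM
compound 2, `CN(C)CCn1cnnc1-c1cc(Oc2ccc(NC(=O)N/N=C/c3cc(Br)c(O)c(Br)c3)cc2F)ccn1`, 2670 nM
compound 3, `CN(C)CCn1cnnc1-c1cc(Oc2ccc(NC(=O)N/N=C/c3ccc(O)c(Br)c3)cc2F)ccn1`, 450 nM

Compound 2 gives the highest number of the three. Its nearest neighbour is compound 3, reached by a 5.9-fold lower number from compound 2 to compound 3 (0.77 log units; beyond the scatter), and compound 1 lies further off, with an 8.1-fold higher number from compound 1 to compound 2 (0.91 log units; beyond the scatter) separating the two. Compound 4, `CN(C)CCn1cnnc1-c1cc(Oc2ccc(NC(=O)N/N=C/c3ccc(O)cc3O)cc2F)ccn1`, has not yet been measured in this assay. The change from compound 2 to compound 4 is 2,4-dihydroxyphenyl in place of 3,5-dibromo-4-hydroxyphenyl on a carbon with a double bond to nitrogen. Within the data shown here, two measured steps bear on it. The step of a 5.9-fold lower number from compound 2 to compound 3 (0.77 log units; beyond the scatter) shows what hydrogen in place of one bromo does, and an 8.1-fold higher number from compound 1 to compound 2 (0.91 log units; beyond the scatter) shows the move from 3-hydroxyphenyl to 3,5-dibromo-4-hydroxyphenyl. Both point the same way: for compound 4, which carries no bromo, a number clearly lower than that of compound 2 is expected, near the numbers of compound 1 and compound 3. Among the measured compounds shown here, no measured pair shows what a second hydroxy does, so the expectation stays near those two. Compound 4 is therefore estimated at 400 nM, with a range from 150 nM to 1200 nM, an expected step of a 6.7-fold lower number from compound 2 to compound 4 (0.82 log units; beyond the scatter).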

Compound 4, half-maximal inhibitory concentration: 52600 nM
Estimate against measurement, compound 4: 130-fold (2.12 log units) below; the measured number lies above the stated range.
By their numbers in this assay, from the lowest: compounds 1 and 3 (each within the scatter of the next); then compound 2; then compound 4.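

In this assay, the aryl group on the carbon with a double bond to nitrogen can shift the number much further than the first three compounds showed: 2,4-dihydroxyphenyl gives a 160-fold higher number from compound 1 to compound 4 (2.20 log units; beyond the scatter) and a 120-fold higher number from compound 3 to compound 4 (2.07 log units; beyond the scatter), both larger than any earlier step. It even gives a 20-fold higher number from compound 2 to compound 4 (1.29 log units; beyond the scatter), so it stands well above the dibromo compound that had held the highest number. Compound 1 and compound 4 both carry no bromo yet lie far apart, so the absence of bromo does not by itself keep the number low at this position, and nothing measured here accounts for the change.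

The compounds shown do not separate the effect of the second hydroxy from that of where the hydroxy groups stand on the ring. They also leave open how this position would respond to a methoxy group, an amine or a carboxylic acid in place of a hydroxy.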